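Thioether Aryl Replacement on a Piperazine Amide Series

A few compounds are considered here, and "the series" means these few. Any claim that something is new, unique, unknown or untested is made for them only; others in the source may bear on it.

Measured compounds:
compound 1 `COc1ccc(OCC(=O)N2CCN(c3ccc(C(F)(F)F)cc3[C@@H](N)CC(C)C)CC2)cc1`: 3800 nM
compound 2 `Cc1cc(Cl)ccc1CC(C)C(=O)N1CCN(c2ccc(C(F)(F)F)cc2[C@@H](N)CC(C)C)CC1`: 38 nM
compound 3 `CC(C)C[C@H](N)c1cc(C(F)(F)F)ccc1N1CCN(C(=O)COc2ccc(O)cc2)CC1`: 4600 nM

In an assay on HEK293 cells for displacement of a labelled ligand from Melanocortin receptor 4 (Homo sapiens) (a higher number here means a weaker inhibitor, a lower number a stronger inhibitor), compound 1 gives 3800 nM, the second highest of the three numbers. Its nearest neighbour is compound 3, where the step of a 1.2-fold higher number from compound 1 to compound 3 (0.08 log units; within the scatter) stays within the scatter. The furthest is compound 2, reached by the step of a 100-fold lower number from compound 1 to compound 2 (2.00 log units; beyond the scatter), a large drop that comes from exchanging the group on the carbonyl carbon for one carrying a chlorinated aromatic ring.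

Compound 4 `CC(C)C[C@H](N)c1cc(C(F)(F)F)ccc1N1CCN(C(=O)CSc2ccc(Cl)cc2Cl)CC1` differs from compound 1 as follows: (2,4-dichlorophenyl)sulfanyl in place of 4-methoxyphenoxy on a saturated chain carbon bound to a carbonyl carbon. This change also sits on the carbonyl side of the shared core and brings in chlorine on the aromatic ring, so the step from compound 1 to compound 2 is the one that bears on it, while the step from compound 1 to compound 3 shows that altering the oxygen substituent alone does little. A downward step is therefore expected, though the two-carbon bridge of compound 2 is not present in compound 4, so the expected step of a 9.5-fold lower number from compound 1 to compound 4 (0.98 log units; beyond the scatter) is smaller. For compound 4 the estimate in this assay is 400 nM, with a range from 80 nM to 2000 nM.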

Compound 4, inhibition constant: 1500 nM
Beside the measured number, compound 4's estimate is 3.8-fold (0.57 log units) below it; the range from low to high includes it.
By their numbers in this assay, from the lowest: compound 2; then compound 4; then compounds 1 and 3 (each within the scatter of the next).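

At the saturated chain carbon bound to a carbonyl carbon, (2,4-dichlorophenyl)sulfanyl gives a modest gain in this assay over 4-methoxyphenoxy (a 2.5-fold lower number from compound 1 to compound 4 (0.40 log units; beyond the scatter)) and over 4-hydroxyphenoxy (a 3.1-fold lower number from compound 3 to compound 4 (0.49 log units; beyond the scatter)). Even so, the ((2,4-dichlorophenyl)sulfanyl)methyl group falls well short of the 1-(4-chloro-2-methylbenzyl)ethyl group on the carbonyl carbon (a 39-fold higher number from compound 2 to compound 4 (1.60 log units; beyond the scatter)), so a chlorinated aromatic ring on this side of the shared core does not by itself recover the potency of compound 2. No measured evidence accompanies these steps to account for their size.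

The change replaces the oxygen with sulfur and alters the ring substituents together, so the compounds shown cannot separate the contribution of the sulfur from that of the chlorine atoms. Going by these compounds, it remains open whether 2,4-dichlorophenoxy or a sulfonyl group in place of the sulfanyl would keep this gain, or whether a longer chain would extend it.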